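Removing One Methoxy Group from Compound 1

The source may report more compounds than this note shows. Statements on the series, on what has been measured and on what is new or still open speak of the compounds shown alone.

Measured in a functional assay on THP-1 cells (Homo sapiens) for inhibition, read by sulforhodamine B assay, with a stated time of 48 h, tested at 50 uM; a higher number here means more inhibition of growth at the concentration tested, a lower number less inhibition of growth:
- compound 1 `COc1ccc(/C=C/C(=O)/C=C/c2ccc(OCc3cn(CCCCOc4cc(=O)oc5ccccc45)nn3)c(OC)c2)cc1OC`: 59%
- compound 2 `COc1cc(/C=C/C(=O)/C=C/c2ccccc2)ccc1OCc1cn(CCCCCOc2cc(=O)oc3ccccc23)nn1`: 26%

Of these two compounds, compound 1 stands highest in this assay, and the gap down to compound 2 lies beyond the usual scatter. Compound 3 `COc1ccc(/C=C/C(=O)/C=C/c2ccc(OCc3cn(CCCCOc4cc(=O)oc5ccccc45)nn3)c(OC)c2)cc1` keeps the core of compound 1 but turns its 3,4-dimethoxyphenyl into 4-methoxyphenyl, with hydrogen in place of methoxy on an aromatic carbon. Within the data shown here, no measured pair shows this change alone, so only a modest fall is expected, possibly none beyond the scatter. The expected change is a number 7 percentage points lower from compound 1 to compound 3 (within the scatter). For compound 3 the estimated value is 52%, within an expected range of 35% to 68%.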

Compound 3, percent growth inhibition at one concentration: 45%
Beside the measured number, compound 3's estimate is 7 percentage points above it; measured number inside the range.
By their numbers in this assay, from the lowest: compound 2; then compound 3; then compound 1.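

Taking one methoxy group off the 3,4-dimethoxyphenyl to leave 4-methoxyphenyl gives a number 14 percentage points lower from compound 1 to compound 3 (beyond the scatter) in this assay. Among these compounds, this is the only comparison here that changes a single place, and it shows that growth inhibition responds to this methoxy group, although compound 3 still reaches 45%. No measurement here explains why the number falls.

Going by these compounds, what a hydroxy group, a fluorine or an amine would do in this place stays open. So does whether the same change would give a similar step on another chain length.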